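A few compounds are considered here, and "the series" means these few. Any claim that something is new, unique, unknown or untested is made for them only; others in the source may bear on it.

Measured in a functional assay on PC-3 cells (Homo sapiens) for cytotoxicity, read by MTT assay; on this read-out lower numbers stand for stronger inhibition and higher numbers for weaker inhibition:
- compound 1 `COc1ccc2cc([C@H](C)c3nnc(SCc4c(C)cc(C)cc4C)n3-c3cccc(Cl)c3)ccc2c1` gives 16300 nM
- compound 2 `COc1ccc2cc([C@H](C)c3nnc(SCc4ccc(C)cc4)n3-c3ccc(F)cc3)ccc2c1` gives 229000 nM
- compound 3 `COc1ccc2cc([C@H](C)c3nnc(SCc4ccc(C)cc4)n3-c3ccc(Cl)cc3)ccc2c1` gives 8400 nM

Compound 2 has the highest number of the three and is the weakest in this assay. Compound 4 `COc1ccc2cc([C@H](C)c3nnc(SCc4c(Cl)cccc4Cl)n3-c3ccc(F)cc3)ccc2c1` departs from it in one place: 2,6-dichlorophenyl in place of 4-methylphenyl on a saturated chain carbon bound to a sulfur. This puts 2,6-dichlorophenyl in place of 4-methylphenyl on a saturated chain carbon bound to a sulfur.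

For the measured compounds named here, no measured step covers this place. Going by the values given here, the only step available, a 27-fold lower number from compound 2 to compound 3 (1.44 log units; beyond the scatter), is a chloro in place of fluoro on an aromatic carbon, a change compound 4 does not make. It bears only indirectly, showing that one change can move the number of compound 2 a long way. Compound 1 carries a different group at the place in question and also differs elsewhere, and it gives 16300 nM.

With compound 2 so far above the other two, a lower number is expected, though the size is uncertain. The estimated change is a 7.6-fold lower number from compound 2 to compound 4 (0.88 log units; beyond the scatter). For compound 4 the expected value is 30000 nM, with an estimated range from 7000 nM to 130000 nM.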

Compound 4, half-maximal inhibitory concentration: 216000 nM
The estimate for compound 4 lay 7.2-fold (0.86 log units) below the measured number; the whole stated range lies below it.
By their numbers in this assay, from the lowest: compounds 3 and 1 (each within the scatter of the next); then compounds 4 and 2 (each within the scatter of the next).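

In this assay, putting 2,6-dichlorophenyl in place of 4-methylphenyl on a saturated chain carbon bound to a sulfur gives a 1.1-fold lower number from compound 2 to compound 4 (0.03 log units; within the scatter), so these two groups cannot be told apart at this place in the fluoro series. This is the first step shown at this place, and the large step in the series remains the chloro in place of fluoro change on an aromatic carbon, a 27-fold lower number from compound 2 to compound 3 (1.44 log units; beyond the scatter). Nothing at hand offers a reason for this result.

The compounds shown leave open whether 2,6-dichlorophenyl and 4-methylphenyl would also read alike alongside the chloro of compound 3. They also leave open how this place would respond to a group of a different kind, such as an amine or a carboxylic acid.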